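Phenyl in Place of the tert-Butoxycarbonyl Aminomethyl Group

The source may report more compounds than this note shows. Statements on the series, on what has been measured and on what is new or still open speak of the compounds shown alone.

Three compounds sharing the same tellurium-bearing side chain have been examined in a functional assay on PC-3 cells (Homo sapiens) for inhibition, with a stated time of 48 h; a lower number here means a stronger inhibitor of growth, a higher number a weaker inhibitor of growth. Compound 1 `COc1ccc(N(CC(=O)NCCC[Te]c2ccccc2)C(=O)CNC(=O)OC(C)(C)C)cc1` gives 10000 nM and stands second highest of the three numbers. Its nearest neighbour is compound 3 `CC1=C(SCCC(=O)OCC(=O)NCCC[Te]c2ccccc2)C(=O)c2ccccc2C1=O`, which gives 12000 nM, a difference within the usual scatter; the two cannot be ordered. Among the measured compounds shown here, compound 2 `COc1ccc(N(CC(=O)NCCC[Te]c2ccccc2)C(=O)CCSC2=C(C)C(=O)c3ccccc3C2=O)cc1` gives 1100 nM, the only number that lies well beyond the scatter from compound 1.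

Compound 4 `COc1ccc(N(CC(=O)NCCC[Te]c2ccccc2)C(=O)c2ccccc2)cc1` has not yet been measured. Relative to compound 1 it differs by phenyl in place of ((tert-butoxycarbonyl)amino)methyl on a carbonyl carbon. For the measured compounds named here, nothing in the measured set follows this single change, so no step of this kind is known. The shared core and side chain are kept, and the part that distinguishes compound 2 is absent from compound 4 as it is from compound 1. Compound 4 is therefore expected to stay close to compound 1, with a step from compound 1 to compound 4 of about a 1.3-fold lower number from compound 1 to compound 4 (0.10 log units; within the scatter), no larger than the scatter in either direction. The estimate for compound 4 is 8000 nM, with a range from 3000 nM to 25000 nM.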

Compound 4, concentration for total growth inhibition: 12600 nM
The estimate for compound 4 lay 1.6-fold (0.20 log units) below the measured number; low and high end bracket the measured number.
By their numbers in this assay, from the lowest: compound 2; then compounds 1, 3 and 4 (each within the scatter of the next).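

In this assay, among the compounds shown here, the step of a 1.3-fold higher number from compound 1 to compound 4 (0.10 log units; within the scatter) is the first in this set to follow a single change, and it shows that phenyl can take the place of ((tert-butoxycarbonyl)amino)methyl on this carbonyl carbon with no difference that can be told from the scatter. The hydrogen-bond donor and acceptors of the group that leaves are gone and an aromatic ring of carbon stands there instead, yet compound 1 and compound 4 cannot be ordered. No measured evidence bears on this result.

Going by these compounds, it remains open whether a free aminomethyl group, a carboxylic acid or a longer chain ending in phenyl on this carbonyl carbon would also stay within the scatter. On these data alone, it is also open whether this exchange would read the same on another core, as it is followed here only once.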